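Second chloro on the shared core: from compound 1 to compound 3

The source may hold more compounds than are shown below. What is called first, only, known or untested is meant among the compounds shown, and "the series" means these compounds.

Measured so far:
compound 1 `ClCc1ccc(Cn2cnc3c(Cl)ncnc32)cc1`: 28800 nM
compound 2 `ClCc1ccccc1Cn1cnc2c(Cl)nc(Cl)nc21`: 3890 nM

Of the compounds shown here, two have been measured. In a functional assay on UACC-257 cells (Homo sapiens) for cytotoxicity, read by sulforhodamine B assay, with a stated time of 48 h (on this read-out lower numbers stand for stronger inhibition of growth and higher numbers for weaker inhibition of growth), compound 1 gives 28800 nM, the highest of the two numbers. Compound 2 gives 3890 nM, and this gap between compound 2 and compound 1 lies beyond the usual scatter. Compound 3 `ClCc1ccc(Cn2cnc3c(Cl)nc(Cl)nc32)cc1` has not yet been measured. It differs from compound 1 by chloro in place of hydrogen on an aromatic carbon. Going by the values given here, no measured pair shows this single change on its own; compound 2 carries the same pair of chloro groups on the shared core but with its substituted benzyl group arranged differently, so its value offers only a loose guide. The step from compound 1 to compound 3 in this assay is expected to be downward, roughly a 3.6-fold lower number from compound 1 to compound 3 (0.56 log units; beyond the scatter), because compound 2 with 3890 nM sits well below compound 1. Compound 3 is therefore estimated at 8000 nM, within a range of 2500 nM to 25000 nM.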

Compound 3, concentration for total growth inhibition: 33100 nM
The estimate for compound 3 lay 4.1-fold (0.62 log units) below the measured number; the measured number lies above the stated range.
By their numbers in this assay, from the lowest: compound 2; then compounds 1 and 3 (each within the scatter of the next).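

In this assay, chloro in place of hydrogen on the aromatic carbon between two ring nitrogen atoms gives a 1.1-fold higher number from compound 1 to compound 3 (0.06 log units; within the scatter) and so leaves the number unchanged within the scatter. The second chloro on its own therefore does not account for the low number of compound 2 at 3890 nM, since compound 2 holds the same pair of chloro groups on the shared core with its substituted benzyl group arranged differently, while compound 3 gives 33100 nM in the same assay. No supporting data bear on why the number stays level here.

On these data alone, it remains open whether an amine or a methoxy group at this position would shift the number. Also open, as far as these compounds go, is whether the same chloro change would count for as little with the benzyl group arranged as in compound 2.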